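The compounds below may be only part of what the source reports. "The series", "measured", "known", "first", "only" and "open" are said of these compounds alone.

In a functional assay on B16 cells (Mus musculus) for inhibition (on this read-out higher numbers stand for weaker inhibition and lower numbers for stronger inhibition), compound 1 `Oc1ccc(-c2csc(NCc3ccccc3)n2)cc1O` gives 2100 nM and compound 2 `Oc1ccc(-c2csc(NCc3ccccc3Cl)n2)cc1O` gives 2000 nM, so compound 2 stands level with compound 1 within the scatter. Compound 3 `Oc1ccc(-c2csc(NCc3cccc(Cl)c3)n2)cc1O` has the same atoms as compound 2, joined differently: 3-chlorophenyl in place of 2-chlorophenyl on a saturated chain carbon bound to a nitrogen on an aromatic ring. Within the data shown here, only one measured step bears on this change, a 1.1-fold lower number from compound 1 to compound 2 (0.02 log units; within the scatter), and it introduced the chloro without a shift beyond the scatter. Among the measured compounds shown here, no measured step compares one chlorophenyl with the other, so no step beyond the scatter is expected in this assay. The expected step is no change at the digits printed from compound 2 to compound 3 (within the scatter). The estimate for compound 3 is 2000 nM, with an expected range of 1000 nM to 4000 nM.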

Compound 3, half-maximal inhibitory concentration: > 50000 nM
Compound 3: a limit, no number; the forecaster's own chance of this, stated with the estimate: 2%; at least 25-fold (1.39 log units) between middle value and limit.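

In this assay compound 3 carries a limit of the assay and not a number: the limit of > 50000 nM in this assay, at which 1 of the 3 values shown sits. The earlier pair showed the chloro leaving compound 2 level with compound 1, so it could not reveal that the chloro's place on the phenyl ring matters here. Going to 3-chlorophenyl gives an at least 25-fold higher number from compound 2 to compound 3 (1.39 log units; beyond the scatter), and the same chloro, set against hydrogen, gives an at least 23-fold higher number from compound 1 to compound 3 (1.37 log units; beyond the scatter). On these data alone, whether a methyl or a methoxy group in place of that chloro would have the same effect stays open. As far as these compounds go, the actual number for compound 3 also stays open.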